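The source may report more compounds than this note shows. Statements on the series, on what has been measured and on what is new or still open speak of the compounds shown alone.

Compound 1, `CCC(C(=O)N1CCN(c2ccccc2Cl)CC1)N1C(=O)CCC1=O`, in a functional assay on the whole organism (strain Swiss) with Mus musculus as the target, in the maximal electroshock model, with a stated time of 2 h, at a dose of 300 mg/kg by the intraperitoneal route (a higher number here means a stronger effect of the compound at the dose given, a lower number a weaker effect), gives 0%.
Compound 2, `CCC(C(=O)N1CCN(c2cccc(F)c2)CC1)N1C(=O)CCC1=O`, in this assay gives 0%.
Compound 3, `CCC(C(=O)N1CCN(c2ccccc2F)CC1)N1C(=O)CCC1=O`, in this assay gives 0%.

Compound 3 stands level with the other two: no change at the digits printed from compound 1 to compound 3 (within the scatter) and no change at the digits printed from compound 2 to compound 3 (within the scatter), both within the scatter. Compound 4, `CCC(C(=O)N1CCN(c2cccc(Cl)c2)CC1)N1C(=O)CCC1=O`, differs from compound 3 by 3-chlorophenyl in place of 2-fluorophenyl on an amine nitrogen in a ring. Among the compounds with values here, three measured steps bear on this: no change at the digits printed from compound 1 to compound 2 (within the scatter), which swaps both halogen and its ring position; no change at the digits printed from compound 1 to compound 3 (within the scatter), halogen alone; and no change at the digits printed from compound 2 to compound 3 (within the scatter), ring position alone. None of them moved the read-out. Moving the chloro to the 3-position of the phenyl is therefore expected to leave compound 4 flat as well, a step of no change at the digits printed from compound 3 to compound 4 (within the scatter) expected. Compound 4 is estimated at 0%, with a range from 0% to 10%.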

Compound 4, a percentage reported as activity, at one dose (the size of the read-out at that dose, not a potency): 25%
Compound 4: the middle estimate sits 25 percentage points below what was measured, outside the stated range (above it).
By their numbers in this assay, from the lowest: compounds 1, 2 and 3 (each within the scatter of the next); then compound 4.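

Within the data shown here, on the amine nitrogen in a ring, 3-chlorophenyl is the only one of the four groups that registers in this assay: 3-fluorophenyl to 3-chlorophenyl gives a number 25 percentage points higher from compound 2 to compound 4 (beyond the scatter), 2-chlorophenyl to 3-chlorophenyl gives a number 25 percentage points higher from compound 1 to compound 4 (beyond the scatter), and 2-fluorophenyl to 3-chlorophenyl gives a number 25 percentage points higher from compound 3 to compound 4 (beyond the scatter). The halogen and its ring position therefore do not act independently, and the same halogen swap does not carry over from one phenyl pattern to the other: the same change on two cores in this assay, no change at the digits printed (within the scatter) from compound 1 to compound 3 and a number 25 percentage points lower (beyond the scatter) from compound 4 to compound 2, 25 percentage points apart, beyond the scatter of two such steps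

On these data alone, whether 3-bromophenyl or 3-methylphenyl would keep this read-out remains open. So does whether the read-out at this one dose reflects potency.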